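A Hexylsulfanyl Analogue in a Series Sitting at the Limit

The source may report more compounds than this note shows. Statements on the series, on what has been measured and on what is new or still open speak of the compounds shown alone.

Compound 1 `Nc1nc(NC2CCCCC2)c2ncn(/C=C3/CC3(CO)CO)c2n1` was examined in an ADME assay on HFF cells (Homo sapiens) for cytotoxicity, with a stated time of 8 days; on this read-out higher numbers stand for lower toxicity in this test and lower numbers for higher toxicity in this test. In this assay compound 1 gives > 300000 nM, which is a limit of the assay rather than a number. Compound 2 `Nc1nc(NC2CC2)c2ncn(/C=C3/CC3(CO)CO)c2n1` is read in this assay at > 300000 nM, again a limit. Compound 3 `Nc1nc(OCC(F)(F)F)c2ncn(/C=C3/CC3(CO)CO)c2n1` gives > 300000 nM in this assay, also a limit. The step that the two limits leave unreadable from compound 1 to compound 2 is therefore not readable, and the same holds for a step that the two limits leave unreadable from compound 1 to compound 3 and for a step that the two limits leave unreadable from compound 2 to compound 3. All three compounds sit at the limit of > 300000 nM in this assay, at which 3 of the 3 values shown sit.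

Compound 4 `CCCCCCSc1nc(N)nc2c1ncn2/C=C1/CC1(CO)CO` differs from compound 1 in one place: hexylsulfanyl in place of cyclohexylamino on an aromatic carbon. Going by the values given here, since every value shown sits at the limit of > 300000 nM in this assay, at which 3 of the 3 values shown sit, none of the measured steps yields a size that could be carried over to this change, and no direction can be read from them. Compound 4 is therefore expected to remain at the same limit in this assay, with an estimated 300000 nM and a range from 80000 nM to 300000 nM. The expected step is a number no higher from compound 1 to compound 4 (the limit leaves the size open), which amounts to no step beyond the scatter.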

Compound 4, half-maximal cytotoxic concentration: > 300000 nM
Compound 4: a limit, no number; the forecaster's own chance of this, stated with the estimate: 75%; the middle value lies on the limit itself.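

Going by these compounds alone, compound 4 also stands at a limit in this assay, so its steps from compound 1, compound 2 and compound 3 cannot be read and no new step follows: the limit of > 300000 nM in this assay, at which 4 of the 4 values shown sit. The compounds shown leave open whether the groups exchanged here differ at all on this read-out.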